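Swapping the Amide Substituent on a Shared Core

A few compounds are considered here, and "the series" means these few. Any claim that something is new, unique, unknown or untested is made for them only; others in the source may bear on it.

Of the compounds shown here, three sharing one core have been tested in a functional assay on A549 cells (Homo sapiens) for inhibition, read by sulforhodamine B assay, with a stated time of 72 h; on this read-out higher numbers stand for weaker inhibition and lower numbers for stronger inhibition. Compound 1 `CC(C)(C)NC(=O)c1c(N)sc(-c2ccc(Cl)cc2)c1-c1ccc(Cl)cc1` gives 8850 nM. Compound 2 `Nc1sc(-c2ccc(Cl)cc2)c(-c2ccc(Cl)cc2)c1C(=O)NC1CCCCC1`, with a cyclohexyl in place of the tert-butyl on the amide-type nitrogen, gives 2410 nM, and compound 3 `Nc1sc(-c2ccc(Cl)cc2)c(-c2ccc(Cl)cc2)c1C(=O)NC1CCC1`, carrying a cyclobutyl there, gives 12500 nM. Among these three numbers compound 1 stands second highest: the step of a 1.4-fold higher number from compound 1 to compound 3 (0.15 log units; within the scatter) lies within the scatter, while a 3.7-fold lower number from compound 1 to compound 2 (0.56 log units; beyond the scatter) is a modest but real gain, and a 5.2-fold higher number from compound 2 to compound 3 (0.71 log units; beyond the scatter) runs the other way.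

Compound 4 `Nc1sc(-c2ccc(Cl)cc2)c(-c2ccc(Cl)cc2)c1C(=O)N1CCCCC1` is not yet measured. It differs from compound 1 in one place: piperidin-1-yl in place of (tert-butyl)amino on a carbonyl carbon. The measured steps that bear on this change are the swaps of the tert-butyl for a six-membered ring, a 3.7-fold lower number from compound 1 to compound 2 (0.56 log units; beyond the scatter), and for a four-membered ring, a 1.4-fold higher number from compound 1 to compound 3 (0.15 log units; within the scatter). Going by the values given here, a six-membered ring has so far given the lower number, but none of the measured compounds carries a piperidin-1-yl on the carbonyl carbon, so that part of the change is untested. The expected step is a 1.8-fold lower number from compound 1 to compound 4 (0.25 log units; within the scatter), which may well stay within the scatter. The estimate for compound 4 in this assay is 5000 nM, with a range from 1500 nM to 20000 nM.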

Compound 4, half-maximal inhibitory concentration: 4620 nM
The estimate for compound 4 lay 1.1-fold (0.03 log units) above the measured number, and the stated range covers the measured number.
By their numbers in this assay, from the lowest: compounds 2, 4, 1 and 3 (each within the scatter of the next, the first and the last beyond it).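

In this assay, piperidin-1-yl on the carbonyl carbon removes the amide hydrogen, the one hydrogen-bond donor that (tert-butyl)amino brought, yet a 1.9-fold lower number from compound 1 to compound 4 (0.28 log units; within the scatter) and a 1.9-fold higher number from compound 2 to compound 4 (0.28 log units; within the scatter) both stay within the scatter. So this position does not need that hydrogen to keep a number in this range, which the earlier compounds could not show, since all of them carry it. The one clear separation is a 2.7-fold lower number from compound 3 to compound 4 (0.43 log units; beyond the scatter), a modest step showing that a six-membered ring joined through its own nitrogen keeps pace with the open-hydrogen amides and does not fall to the level of the cyclobutyl compound, though nothing available here explains this result.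

What the compounds leave open is how far this tolerance extends on the carbonyl carbon: a pyrrolidin-1-yl would test a smaller ring joined through its nitrogen, and a morpholin-4-yl would test an oxygen in the ring. A piperazine or a carboxylic acid on the ring would show whether a charged group is accepted at this position in this assay.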